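Replacing the methacryloyl urea of compound 2 with an ethyl urea

The source may report more compounds than this note shows. Statements on the series, on what has been measured and on what is new or still open speak of the compounds shown alone.

Of the compounds shown here, three sharing one core have been tested in a functional assay on HEL cells (Homo sapiens) for cytotoxicity, read by microscopy; on this read-out lower numbers stand for higher toxicity in this test and higher numbers for lower toxicity in this test. Compound 1 `COC(=O)CNC1=CS(=O)(=O)O[C@@]12[C@@H](CO[Si](C)(C)C(C)(C)C)O[C@@H](n1cc(C)c(=O)n(C)c1=O)[C@@H]2O[Si](C)(C)C(C)(C)C` gives only a limit of the assay, >= 400000 nM. Compound 2 `C=C(C)C(=O)NC(=O)NC1=CS(=O)(=O)O[C@@]12[C@@H](CO[Si](C)(C)C(C)(C)C)O[C@@H](n1cc(C)c(=O)n(C)c1=O)[C@@H]2O[Si](C)(C)C(C)(C)C` gives 20000 nM, the lowest number among the two numbers shown, and compound 3 `COC(=O)CC(=O)NC1=CS(=O)(=O)O[C@@]12[C@@H](CO[Si](C)(C)C(C)(C)C)O[C@@H](n1cc(C)c(=O)n(C)c1=O)[C@@H]2O[Si](C)(C)C(C)(C)C` gives 400000 nM. The two steps with a readable size are both large and point in opposite directions: an at least 20-fold lower number from compound 1 to compound 2 (1.30 log units; beyond the scatter) and a 20-fold higher number from compound 2 to compound 3 (1.30 log units; beyond the scatter). The low number of compound 2 therefore goes with the group it alone carries.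

Compound 4 `CCNC(=O)NC1=CS(=O)(=O)O[C@@]12[C@@H](CO[Si](C)(C)C(C)(C)C)O[C@@H](n1cc(C)c(=O)n(C)c1=O)[C@@H]2O[Si](C)(C)C(C)(C)C` has not yet been measured. It differs from compound 2 in one place: ethyl in place of (1-methylethenyl)carbonyl on an amide-type nitrogen. Compound 4 keeps the urea link but loses the group that compound 2 alone carries, so the step from compound 2 is expected to run back upward, as in a 20-fold higher number from compound 2 to compound 3 (1.30 log units; beyond the scatter), toward the numbers of compound 1 and compound 3. For compound 4 a large rise is expected, a 10-fold higher number from compound 2 to compound 4 (1.00 log units; beyond the scatter), giving an estimate of 200000 nM, with a range from 50000 nM to 400000 nM.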

Compound 4, minimum cytotoxic concentration: >= 3200 nM
Compound 4 was reported as a limit (the forecaster's own chance of this, stated with the estimate: 40%); the middle value lies beyond the limit too.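

Compound 4 is reported only as a limit, so its steps to compound 1, compound 2 and compound 3 cannot be read: the limit of >= 3200 nM in this assay, at which 1 of the 4 values shown sits.

The compounds shown leave open whether the number for compound 4 lies nearer that of compound 2 or that of compound 3.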